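The source may hold more compounds than are shown below. What is called first, only, known or untested is meant among the compounds shown, and "the series" means these compounds.

Compound 3 `CC(C)c1nc(Nc2ccccc2)c2cnn(-c3ccccc3)c2n1` is the point of departure. Among the compounds with values here, in a functional assay on G-361 cells (Homo sapiens) for cytotoxicity, read by sulforhodamine B assay (a higher number here means a weaker inhibitor of growth, a lower number a stronger inhibitor of growth), compound 3 gives 32000 nM, and this is the only number in the set. Compound 1 `Cc1nc(Nc2ccccc2)c2cnn(-c3ccccc3)c2n1` reaches only the limit > 100000 nM in this assay. Compound 2 `CCCCNc1nc(C(C)C)nc2c1cnn2-c1ccccc1` likewise stops at the limit > 100000 nM in this assay. Within the data shown here, both limits sit at the limit of > 100000 nM in this assay, at which 2 of the 3 values shown sit, so compound 3 is the one compound whose growth inhibition was resolved into a number.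

Two steps lead into compound 3. The step of an at least 3.1-fold lower number from compound 1 to compound 3 (0.49 log units; beyond the scatter) and the step of an at least 3.1-fold lower number from compound 2 to compound 3 (0.49 log units; beyond the scatter) both move toward compound 3, each beyond the scatter, and each is a lower bound, as the starting points are limits.

Compound 4 `c1ccc(NCc2nc(Nc3ccccc3)c3cnn(-c4ccccc4)c3n2)cc1` differs from compound 3 in one place: anilinomethyl in place of isopropyl on an aromatic carbon. Among the measured compounds shown here, of the two measured steps, the one from compound 1 to compound 3 touches the same aromatic carbon; it shows that a larger group there brought the number down by a modest amount at least. The change to anilinomethyl is not of the same kind, so the expectation rests loosely on that step. Compound 4 is expected to give about 15000 nM in this assay, within 3000 nM to 100000 nM, and the expected step of a 2.1-fold lower number from compound 3 to compound 4 (0.33 log units; beyond the scatter) is therefore small and toward a lower number.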

Compound 4, concentration for 50% growth inhibition: > 100000 nM
Compound 4: no number, only a limit; the forecaster's own chance of this, stated with the estimate: 25%; at least 6.6-fold (0.82 log units) between middle value and limit.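

Within the data shown here, at the aromatic carbon between two ring nitrogen atoms, the earlier compounds showed only that isopropyl in place of methyl brought growth inhibition into a readable range, whereas anilinomethyl in place of isopropyl reverses that direction, with an at least 3.1-fold higher number from compound 3 to compound 4 (0.49 log units; beyond the scatter) in this assay. Among these compounds, a larger group at this carbon therefore does not by itself lower the number: anilinomethyl adds a six-membered aromatic ring and a hydrogen-bond donor, and compound 3 remains the only compound with a resolved value. The step from compound 1 to compound 4 cannot be read, as both ends are limits, and the set now rests on a single number: the limit of > 100000 nM in this assay, at which 3 of the 4 values shown sit.

The compounds shown leave open how narrow the range of groups accepted at this carbon is, and whether ethyl, cyclopropyl or tert-butyl would match isopropyl. They also leave open whether the ring or the nitrogen of anilinomethyl accounts for the higher number, a question that a phenethyl group or a plain aminomethyl group could separate.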